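Alkyl Chain Extension in a Trihydroxyphenyl Ketone Series

The source may report more compounds than this note shows. Statements on the series, on what has been measured and on what is new or still open speak of the compounds shown alone.

The series shares one core and differs only in the length of a saturated chain attached to the carbonyl. Compound 1 is `CCCCCCCCC(=O)c1cc(O)c(O)c(O)c1`, compound 2 is `CCCCCCCCCCC(=O)c1cc(O)c(O)c(O)c1` and compound 3 is `CCCCCCCCCCCCCCC(=O)c1cc(O)c(O)c(O)c1`. Compound 2 differs from compound 1 by ethyl in place of hydrogen on a saturated chain carbon, eight bonds along the chain from a carbonyl carbon. Compound 3 differs from compound 1 by hexyl in place of hydrogen on a saturated chain carbon, eight bonds along the chain from a carbonyl carbon.

In an ADME assay on Vero cells (Chlorocebus sabaeus) for cytotoxicity (on this read-out higher numbers stand for weaker inhibition and lower numbers for stronger inhibition), compound 1 gives > 1000 nM, which is a limit of the assay and not a number. In this assay compound 2 gives > 1000 nM, again a limit. In this assay compound 3 gives > 1000 nM, also a limit. Because of this, a step that the two limits leave unreadable from compound 1 to compound 2, a step that the two limits leave unreadable from compound 1 to compound 3 and a step that the two limits leave unreadable from compound 2 to compound 3 are all unreadable in size. What the three measured compounds do show is the limit of > 1000 nM in this assay, at which 3 of the 3 values shown sit.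

Compound 4, `CCCCCCCCCCCCCCCCC(=O)c1cc(O)c(O)c(O)c1`, is not yet measured. It differs from compound 3 by ethyl in place of hydrogen on a saturated chain carbon, ten or more bonds along the chain from a carbonyl carbon. This is the same kind of change as that from compound 1 to compound 2, though its place on the chain differs, as the two differences just given show.

Because (the limit of > 1000 nM in this assay, at which 3 of the 3 values shown sit), the step from compound 3 to compound 4 in this assay is expected to be a step that the limit leaves unreadable from compound 3 to compound 4, with the value most likely again reported as a limit. Compound 4 is estimated at 3000 nM in this assay, expected to fall between 1000 nM and 20000 nM.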

Compound 4, half-maximal inhibitory concentration: > 1000 nM
Compound 4: only a limit was reported; the forecaster's own chance of this, stated with the estimate: 85%; the middle value does not contradict the limit.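

In this assay compound 4 gives > 1000 nM, a limit of the assay and not a number. The steps to compound 4 from compound 1, compound 2 and compound 3 cannot be read in size, and the series stays at one limit: the limit of > 1000 nM in this assay, at which 4 of the 4 values shown sit.

The compounds shown leave open whether any chain length in this series gives a measured value in this assay, and how large any step along the chain is.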